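Chain length between aryl ether and pyrrolidine in flavone analogues

This account rests on a few compounds, and the source may have more. Where it says the series, first, only, none or still open, it means among the compounds named here.

Measured compounds:
compound 1 `COc1ccccc1-c1cc(=O)c2c(O)cc(OCCCCN3CCN(C)CC3)c(OC)c2o1` 9300 nM
compound 2 `O=c1cc(-c2ccccc2)oc2c(OCCCN3CCCC3)c(OCc3ccccc3)cc(O)c12` 7980 nM

In a functional assay on B16 cells (Mus musculus) for cytotoxicity, read by MTT assay, with a stated time of 72 h (on this read-out lower numbers stand for stronger inhibition and higher numbers for weaker inhibition), compound 2 gives 7980 nM and compound 1 gives 9300 nM; the two numbers lie within the scatter of each other, so neither can be placed ahead of the other. Compound 3 `O=c1cc(-c2ccccc2)oc2c(OCCCCN3CCCC3)c(OCc3ccccc3)cc(O)c12` has not been measured. The change from compound 2 to compound 3 is (pyrrolidin-1-yl)methyl in place of pyrrolidin-1-yl on a saturated chain carbon, three bonds along the chain from an oxygen on an aromatic ring. Among the compounds with values here, no comparable step among the measured compounds shows what lengthening this chain does, so the expectation rests on compound 2 alone. In this assay compound 3 is expected to give 7500 nM (range 3500 nM to 16000 nM), a step of a 1.1-fold lower number from compound 2 to compound 3 (0.03 log units; within the scatter) that is estimated not to go beyond the scatter.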

Compound 3, half-maximal inhibitory concentration: 3210 nM
Compound 3: the middle estimate sits 2.3-fold (0.37 log units) above what was measured; measured number outside the range, below it.
By their numbers in this assay, from the lowest: compound 3; then compounds 2 and 1 (each within the scatter of the next).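

Lengthening the chain from 3-(pyrrolidin-1-yl)propyl to 4-(pyrrolidin-1-yl)butyl lowers the number in this assay (a 2.5-fold lower number from compound 2 to compound 3 (0.40 log units; beyond the scatter)). Within the data shown here, this gives the first reading of this chain on its own, which compounds 1 and 2, differing in more than one place, could not give. No measurement at hand accounts for the step.

From the compounds shown here alone, whether a shorter 2-(pyrrolidin-1-yl)ethyl chain or a longer chain would continue this direction remains open. So does whether a piperidine or a morpholine in place of the pyrrolidine would respond in the same way to this change.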